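This account rests on a few compounds, and the source may have more. Where it says the series, first, only, none or still open, it means among the compounds named here.

Measured so far:
compound 1 `COc1cccc(CNC(=O)c2cc3ccc(-c4cn[nH]c4)nc3n2CCN(C)C)c1` — 243 nM
compound 2 `COc1cccc(CN(C(=O)c2c[nH]c3nc(-c4cn[nH]c4)ccc23)C2CC2)c1` — 30 nM

In an assay on isolated protein for inhibition of Rho-associated protein kinase 1 (Homo sapiens) (a lower number here means a stronger inhibitor, a higher number a weaker inhibitor), compound 2 gives 30 nM and stands with the lowest of the two numbers in hand; compound 1 gives 243 nM, a higher number, and the gap between the two lies beyond the scatter. For the measured compounds named here, compound 1 and compound 2 differ in more than one place, so no single step between them is set out and the two values are left to speak for themselves.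

Compound 3 `COc1cccc(CN(CCCN2CCN(C)CC2)C(=O)c2c[nH]c3nc(-c4cn[nH]c4)ccc23)c1` is the next compound to be measured in this assay. It differs from compound 2 in one place: 3-(4-methylpiperazin-1-yl)propyl in place of cyclopropyl on an amide-type nitrogen

Going by the values given here, no measured pair shows a change of this kind, so the size of the step can only be guessed. The shared core and the rest of compound 2 are kept, and the expectation is a step of modest size, most likely within the scatter or a little towards a higher number. The value for compound 3 is estimated at 50 nM, with a range from 12 nM to 200 nM, which would mean an expected step of a 1.7-fold higher number from compound 2 to compound 3 (0.22 log units; within the scatter).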

Compound 3, half-maximal inhibitory concentration: 260 nM
Compound 3: the middle estimate sits 5.2-fold (0.72 log units) below what was measured; the whole stated range lies below it.
By their numbers in this assay, from the lowest: compound 2; then compounds 1 and 3 (each within the scatter of the next).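

On the amide-type nitrogen of the shared core, 3-(4-methylpiperazin-1-yl)propyl in place of cyclopropyl weakens inhibition in this assay, with an 8.7-fold higher number from compound 2 to compound 3 (0.94 log units; beyond the scatter), so the group at this position is not neutral to the read-out. The weakening is partial: with the much larger substituent, compound 3 still gives 260 nM. Nothing at hand accounts for the size of this step.

The step replaces the three-membered ring with a propyl chain, a piperazine ring and its methyl group all at once, and the compounds shown do not separate these parts. On the same nitrogen, a shorter ethyl chain ending in a dimethylamine, or a propyl chain ending in a morpholine or a hydroxyl group, would show which part tracks with the step.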